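Swapping chloro for bromo on a sulfonyl-bearing phenyl ring

The source may hold more compounds than are shown below. What is called first, only, known or untested is meant among the compounds shown, and "the series" means these compounds.

Measured so far:
compound 1 `O=C1/C(=C/c2cccnc2)CN(S(=O)(=O)c2ccc(Cl)cc2)C/C1=C\c1ccccc1F` — 12100 nM
compound 2 `O=C1/C(=C/c2cccnc2)CN(S(=O)(=O)c2ccc(Br)cc2)C/C1=C\c1ccccc1F` — 12800 nM
compound 3 `O=C1/C(=C/c2ccncc2)CN(S(=O)(=O)c2ccc(Cl)cc2)C/C1=C\c1ccccc1F` — 12500 nM

All three were tested in a functional assay on QGY-7703 cells (Homo sapiens) for cytotoxicity, read by MTT assay, with a stated time of 24 h; a lower number here means a stronger inhibitor, a higher number a weaker inhibitor. The values of compound 1, compound 2 and compound 3 lie close together, and each step between them is within the usual scatter.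

Compound 1 and compound 2 share one core and differ at a single spot: bromo in place of chloro on an aromatic carbon. That change gave a 1.1-fold higher number from compound 1 to compound 2 (0.02 log units; within the scatter), so the measured result barely moved.

Compound 3 carries a different core from compound 1. The cores differ as follows: pyridin-4-yl in place of pyridin-3-yl on a double-bonded chain carbon bound to a double-bonded ring carbon. This change gave a 1.0-fold higher number from compound 1 to compound 3 (0.01 log units; within the scatter), again within the scatter.

Compound 4 `O=C1/C(=C/c2ccncc2)CN(S(=O)(=O)c2ccc(Br)cc2)C/C1=C\c1ccccc1F` has not yet been measured. It differs from compound 3 in this way: bromo in place of chloro on an aromatic carbon. The place of this change is described in the same words as for the change from compound 1 to compound 2, so it is the same change, carried out on the core of compound 3 instead of the core of compound 1.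

Because a 1.1-fold higher number from compound 1 to compound 2 (0.02 log units; within the scatter) showed almost no movement for this change on the core of compound 1, a similar outcome is expected on the core of compound 3, and the step expected from compound 3 to compound 4 is a 1.1-fold higher number from compound 3 to compound 4 (0.02 log units; within the scatter). Compound 4 is therefore estimated to give 13200 nM in this assay, with a likely range from 8000 nM to 22000 nM.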

Compound 4, half-maximal inhibitory concentration: 11500 nM
Beside the measured number, compound 4's estimate is 1.1-fold (0.06 log units) above it, within the range that was stated.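

In this assay, bromo in place of chloro gave a 1.1-fold lower number from compound 3 to compound 4 (0.04 log units; within the scatter), and this step matches the one seen on the core of compound 1: the same change on two cores in this assay, a 1.1-fold higher number (0.02 log units; within the scatter) from compound 1 to compound 2 and a 1.1-fold lower number (0.04 log units; within the scatter) from compound 3 to compound 4, 1.1-fold (0.06 log units) apart, within the scatter of two such steps. Pyridin-4-yl in place of pyridin-3-yl gave a 1.1-fold lower number from compound 2 to compound 4 (0.05 log units; within the scatter), and this step also matches its earlier counterpart: the same change on two cores in this assay, a 1.0-fold higher number (0.01 log units; within the scatter) from compound 1 to compound 3 and a 1.1-fold lower number (0.05 log units; within the scatter) from compound 2 to compound 4, 1.1-fold (0.06 log units) apart, within the scatter of two such steps. So each change behaves alike on the two cores in the narrow sense that it leaves the number within the scatter on both; this does not show that a change with a real effect would carry over in the same way, and it says nothing about any other core.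

The compounds shown leave open whether any group at these two spots can move the number beyond the scatter, as all four hold only chloro or bromo on the phenyl ring of the sulfonyl group and only pyridin-3-yl or pyridin-4-yl on the double-bonded chain carbon. An amine or a carboxylic acid in place of the halogen, or a plain phenyl in place of the pyridinyl group, would test this, and a change of that kind could then be compared across the two cores.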